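This account rests on a few compounds, and the source may have more. Where it says the series, first, only, none or still open, it means among the compounds named here.

Measured so far in a functional assay on the whole organism with Rattus norvegicus as the target, at a dose of 40 mg/kg by the intraperitoneal route; a higher number here means more inhibition at the dose given (going by the name of the read-out), a lower number less inhibition:
compound 1, `Cc1nc2c(OCc3ccccc3)cccn2c1N`: 99%
compound 2, `Cc1nc2c(OCc3ccccc3F)cccn2c1N`: 93%
compound 3, `Cc1nc2c(OCc3ccsc3)cccn2c1N`: 52%

Compound 1 gives the highest of the three numbers; the nearest is a number 6 percentage points lower from compound 1 to compound 2 (within the scatter), the furthest a number 47 percentage points lower from compound 1 to compound 3 (beyond the scatter). Compound 4, `CCCN(CCC)c1c(C)nc2c(OCc3ccccc3)cccn12`, is not yet measured. It differs from compound 1 in one place: dipropylamino in place of amino on an aromatic carbon. Neither measured step touches this amino group: the small step alters the phenyl group, the large step exchanges it. Among the compounds with values here, no measured step therefore bears on the change, and the expectation rests on compound 1 alone. A downward step of uncertain size is expected, a number 34 percentage points lower from compound 1 to compound 4 (beyond the scatter). Compound 4 is estimated at 65%, with a range from 20% to 98%.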

Compound 4, a percentage reported as inhibition, in the whole organism at one dose (the size of the read-out at that dose, not a potency): 60%
Compound 4: the middle estimate sits 5 percentage points above what was measured, and the stated range covers the measured number.
By their numbers in this assay, from the lowest: compounds 3 and 4 (each within the scatter of the next); then compounds 2 and 1 (each within the scatter of the next).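

In this assay this position on the five-membered ring turns out not to be indifferent to its substituent: dipropylamino in place of amino gives a number 39 percentage points lower from compound 1 to compound 4 (beyond the scatter). Inhibition does not vanish, although the swap replaces 1 heavy atom with 7 and leaves 0 hydrogen-bond donors on this group. Nothing measured here explains the drop. Going by these compounds, whether the size of the new group or the loss of the donor matters remains open. Methylamino, which keeps a donor, or a single propylamino chain would help separate the two.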